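A few compounds are considered here, and "the series" means these few. Any claim that something is new, unique, unknown or untested is made for them only; others in the source may bear on it.

Measured so far:
compound 1, `C=CCCCCC/C=C\C(O)C#CC#CC(O)C=C`, 0.12 ug/mL
compound 2, `C=CCCCCC/C=C\[C@H](O)C#CC#CC1OC1C`, 3.3 ug/mL
compound 3, `C=CCCCCC/C=C/[C@H](O)C#CC#C[C@@H](O)[C@H](C)O`, 9.6 ug/mL

All three compounds were tested in a functional assay on L1210 cells (Mus musculus) for cytotoxicity, read by WST assay, with a stated time of 48 h; a lower number here means that less compound is needed, a higher number that more compound is needed for the effect. Compound 2 stands second highest of the three numbers. Its nearest neighbour is compound 3, whose higher number lies beyond the usual scatter, and its furthest neighbour is compound 1, whose much lower number also lies well beyond the scatter. Among the measured compounds shown here, no two of the measured compounds differ in just one place, so no measured step is available to guide the next comparison directly.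

Compound 4, `C=CCCCCC/C=C\[C@H](O)C#CC#C[C@H](C=C)OC(C)=O`, has not yet been measured. It differs from compound 2 as follows: a group of 7 heavy atoms (5 carbon, 2 oxygen; no ring) in place of a group of 4 heavy atoms (3 carbon, 1 oxygen; one three-membered non-aromatic ring with 1 hetero atom), on a triple-bonded carbon. With this change compound 4 comes closer in build to compound 1 than compound 2 is, and compound 1 gives 0.12 ug/mL in this assay. On that basis a step downward, beyond the scatter, is expected from compound 2 to compound 4, though not necessarily all the way to compound 1, since the entering group is not the same as that of compound 1; the expected step is a 5.5-fold lower number from compound 2 to compound 4 (0.74 log units; beyond the scatter). Compound 4 is therefore estimated at 0.6 ug/mL, with a likely range from 0.1 ug/mL to 3 ug/mL.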

Compound 4, concentration for half-maximal effect: 2.1 ug/mL
Compound 4: middle estimate off by 3.5-fold (0.54 log units), on the low side; the measured number falls inside the stated range.
By their numbers in this assay, from the lowest: compound 1; then compounds 4 and 2 (each within the scatter of the next); then compound 3.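

In this assay, a 1.6-fold lower number from compound 2 to compound 4 (0.20 log units; within the scatter) stays within the usual scatter, so on this triple-bonded carbon the two groups cannot be told apart by their numbers. The step therefore shows that the three-membered ring of 3-methyloxiran-2-yl is not required for a number at this level: a group of 7 heavy atoms with no ring and 2 double bonds, as in compound 4, gives 2.1 ug/mL. Nothing at hand explains why two such different groups give numbers this close.

The compounds shown leave open whether this position accepts almost any group or only some, for instance whether an amine or a carboxylic acid on the same triple-bonded carbon would also stay within the scatter of compound 2. They also leave open whether the defined stereocentre of the entering group matters, since a single step with one spatial arrangement of that group cannot say how the opposite arrangement would read in this assay.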